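This account rests on a few compounds, and the source may have more. Where it says the series, first, only, none or still open, it means among the compounds named here.

Working notes on the chalcone-type series

Of the compounds shown here, two carry numbers so far. Compound 1 `COc1ccc(C(=O)/C=C/c2cn(-c3ccccc3)nc2-c2ccsc2)cc1OC` is the one with an aryl ketone on the shared core; in a functional assay on HCT-116 cells (Homo sapiens) for inhibition, read by sulforhodamine B assay, with a stated time of 72 h (on this read-out higher numbers stand for weaker inhibition and lower numbers for stronger inhibition), compound 1 gives 1600 nM. Compound 2 `O=C(/C=C/c1cn(-c2ccccc2)nc1-c1cccnc1)c1cc[nH]c1` carries the pyrrolyl ketone instead and a pyridyl on the core; in this assay compound 2 gives 7400 nM, the higher of the two numbers, and the gap to compound 1 lies beyond the usual scatter of the read-out.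

Compound 3 `COc1ccc(OC)c(C(=O)/C=C/c2cn(-c3ccccc3)nc2-c2cccnc2)c1` is the next member, not yet measured. It keeps the pyridyl of compound 2 and changes only the ketone side: 2,5-dimethoxyphenyl in place of 1H-pyrrol-3-yl on a carbonyl carbon. Within the data shown here, no measured pair in the set shows this exact exchange, so its size can only be inferred from compound 1, whose dimethoxyphenyl ketone sits at 1600 nM while compound 2 sits at 7400 nM.

On that basis the step from compound 2 to compound 3 is expected to move toward a lower number, by about a 3.0-fold lower number from compound 2 to compound 3 (0.47 log units; beyond the scatter), beyond the scatter but not by a large margin. For compound 3 the estimate in this assay is 2500 nM, with a plausible range from 800 nM to 8000 nM.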

Compound 3, half-maximal inhibitory concentration: 1000 nM
Compound 3: the middle estimate sits 2.5-fold (0.40 log units) above what was measured; the measured number falls inside the stated range.
By their numbers in this assay, from the lowest: compounds 3 and 1 (each within the scatter of the next); then compound 2.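

With the rest of the structure held fixed, placing 2,5-dimethoxyphenyl in place of 1H-pyrrol-3-yl on a carbonyl carbon gives in this assay a clear change (a 7.4-fold lower number from compound 2 to compound 3 (0.87 log units; beyond the scatter)), so this position on the ketone side affects the read-out on its own. Compounds 1 and 2 differ in more than one place, so their gap could not be assigned to this position, whereas this single exchange can be: the entering group has 10 heavy atoms against 5, has 2 hydrogen-bond acceptors and no donor where the leaving group has 1 donor and no acceptor, and is a six-membered aromatic ring of carbon only rather than a five-membered aromatic ring with 1 hetero atom. No supporting measurement accompanies the step, and it cannot be tied to any one of these differences.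

The compounds shown leave open whether the gain needs both methoxy groups, which a phenyl ketone with a single methoxy group or none would test, and whether a hydroxyl in place of a methoxy group would give a similar number. Also open, on these data alone, is whether the same exchange gives a step of similar size when the rest of the core differs.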